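This account rests on a few compounds, and the source may have more. Where it says the series, first, only, none or still open, it means among the compounds named here.

Three compounds have so far been measured in a functional assay on A549 cells (Homo sapiens) for inhibition, read by sulforhodamine B assay, tested at 10 uM; a lower number here means less inhibition of growth, a higher number more inhibition of growth at the concentration tested:

compound 1, `COc1cc(C2CC(c3ccc(OCc4cn(Cc5ccc([N+](=O)[O-])cc5)nn4)cc3)=NN2C(C)=O)ccc1Oc1cn(Cc2ccc([N+](=O)[O-])cc2)nn1`: 29%
compound 2, `COc1ccc(C2CC(c3ccc(OCc4cn(Cc5ccc([N+](=O)[O-])cc5)nn4)cc3)=NN2C(C)=O)cc1`: 26%
compound 3, `COc1cc(C2CC(c3ccc([N+](=O)[O-])cc3)=NN2C(C)=O)ccc1OCc1cn(Cc2ccc([N+](=O)[O-])cc2)nn1`: 39%

Compound 3 gives the highest of the three numbers. Its nearest neighbour is compound 1, whose number lies within the scatter of repeated measurements, so the two cannot be told apart. Compound 2 sits further away, beyond the scatter, so compound 3 is clearly stronger than compound 2 in this assay.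

Compound 4, `COc1cc(C2CC(c3ccc(Br)cc3)=NN2C(C)=O)ccc1OCc1cn(Cc2ccc([N+](=O)[O-])cc2)nn1`, has not been measured yet. It differs from compound 3 in one place: bromo in place of nitro on an aromatic carbon, para to a large group. Within the data shown here, no pair among the measured compounds shows this change, so there is no measured step to lean on. Among the measured compounds shown here, with only one group swapped on the far end of the structure, the expected step from compound 3 to compound 4, a number 6 percentage points lower from compound 3 to compound 4 (within the scatter), is small and is not expected to exceed the scatter, leaning slightly downward. Compound 4 is therefore estimated at 33%, within a range from 18% to 48%.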

Compound 4, percent growth inhibition at one concentration: 0%
For compound 4 the middle estimate is 33 percentage points above the measured one, and the stated range ends above it.
By their numbers in this assay, from the lowest: compound 4; then compounds 2, 1 and 3 (each within the scatter of the next, the first and the last beyond it).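

Swapping nitro for bromo on this ring is the first single change that can be read in this assay, and it gives a number 39 percentage points lower from compound 3 to compound 4 (beyond the scatter). The position, para to a large group, is therefore not a place where any substituent will do: with the rest of the structure unchanged, this one change removes all the growth inhibition seen at the concentration tested. Nothing available here says why these two groups differ so sharply.

On these data alone, whether an amine, a carboxylic acid or a nitrile at this position would keep the inhibition or lose it as bromo does remains open. This is also a single pair, so it cannot show whether the same swap would cost as much on a different core.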